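Dichlorophenyl in place of fluorophenyl on the thioether

The compounds below may be only part of what the source reports. "The series", "measured", "known", "first", "only" and "open" are said of these compounds alone.

Of the compounds shown here, three sharing one core have been measured in a functional assay on NCI-H23 cells (Homo sapiens) for inhibition, read by sulforhodamine B assay, with a stated time of 48 h; on this read-out higher numbers stand for weaker inhibition of growth and lower numbers for stronger inhibition of growth. Compound 1 `Nc1cc(N)c2nc(-c3ccccc3)c(NCc3ccc(Cl)c(Cl)c3)nc2c1` gives 27500 nM. Compound 2 `Nc1cc(N)c2nc(-c3ccccc3)c(Sc3ccc(F)cc3)nc2c1` gives 39800 nM, the highest number of the three, though the value of compound 1 lies within the usual scatter of it. Compound 3 `COc1cc(CNc2nc3cc(N)cc(N)c3nc2-c2ccccc2)cc(OC)c1OC` gives 17000 nM, a number lower than that of compound 2 by more than the scatter.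

Compound 4 `Nc1cc(N)c2nc(-c3ccccc3)c(Sc3ccc(Cl)c(Cl)c3)nc2c1` has not been measured in this assay. It differs from compound 2 in one place: 3,4-dichlorophenyl in place of 4-fluorophenyl on a sulfur. Within the data shown here, no measured pair shows this change on the sulfur, so nothing among the three values directly tells its size. Compound 1 carries a 3,4-dichlorophenyl group on a different linker and gives 27500 nM, which is within the scatter of compound 2, so the account expects a step from compound 2 to compound 4 of a 1.3-fold lower number from compound 2 to compound 4 (0.12 log units; within the scatter), small and possibly not beyond the scatter. For compound 4 the estimated value in this assay is 30000 nM, with a range from 12000 nM to 80000 nM.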

Compound 4, concentration for total growth inhibition: 34700 nM
For compound 4 the middle estimate is 1.2-fold (0.06 log units) below the measured one; low and high end bracket the measured number.
By their numbers in this assay, from the lowest: compounds 3, 1, 4 and 2 (each within the scatter of the next, the first and the last beyond it).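

In this assay the change on the sulfur can now be read directly: a 1.1-fold lower number from compound 2 to compound 4 (0.06 log units; within the scatter). Among these compounds, on this position, 3,4-dichlorophenyl and 4-fluorophenyl therefore cannot be told apart, so the larger group with two chlorines in place of one fluorine brings no step that stands out from the scatter. Nothing available on the properties of these compounds bears on this result.

The two aryl groups shown on the sulfur are both halogen-substituted phenyl rings, so it remains open whether a plain phenyl ring, or a ring carrying an amine or a carboxylic acid, would read differently. As far as these compounds go, it is also open whether a longer alkyl chain on the sulfur, with no aromatic ring at all, would shift the number beyond the scatter.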